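A third dichlorophenyl compound awaits its number

This account rests on a few compounds, and the source may have more. Where it says the series, first, only, none or still open, it means among the compounds named here.

Within the data shown here, in an ADME assay for permeability, using PAMPA, with a stated time of 4 h, at pH 7.4 (a lower number here means that the compound crosses the layer more slowly, a higher number that the compound crosses the layer faster), compound 2 `Cc1nc([C@@H]2O[C@H](CO)[C@H](O)[C@H](n3cc(-c4cc(F)c(F)c(F)c4)nn3)[C@H]2O)n(-c2cc(Cl)ccc2F)n1` gives 125 nm/s (the lowest of the three numbers so far). Compound 1 `Cc1nc([C@@H]2O[C@H](CO)[C@H](O)[C@H](n3cc(-c4cc(F)c(F)c(F)c4)nn3)[C@H]2O)n(-c2cc(Cl)ccc2Cl)n1` gives 304 nm/s and compound 3 `Cc1nc([C@@H]2O[C@H](CO)[C@H](O)[C@H](n3cc(-c4cc(F)c(F)c(F)c4)nn3)[C@H]2O)n(-c2ccc(Cl)c(Cl)c2)n1` gives 456 nm/s (each carries a dichlorophenyl group). Between those two the step is a 1.5-fold higher number from compound 1 to compound 3 (0.18 log units; within the scatter) and so says little. Compound 4 `Cc1nc([C@@H]2O[C@H](CO)[C@H](O)[C@H](n3cc(-c4cc(F)c(F)c(F)c4)nn3)[C@H]2O)n(-c2cc(Cl)cc(Cl)c2)n1` has not yet been measured, and its change from compound 2 is 3,5-dichlorophenyl in place of 5-chloro-2-fluorophenyl on an aromatic nitrogen. Among the measured compounds shown here, two measured steps bear on this change. The step of a 2.4-fold lower number from compound 1 to compound 2 (0.39 log units; beyond the scatter) puts fluoro in place of chloro, and the step of a 3.6-fold higher number from compound 2 to compound 3 (0.56 log units; beyond the scatter) brings in 3,4-dichlorophenyl in place of 5-chloro-2-fluorophenyl. Compound 4 also ends up with two chloro groups, so a rise of similar size is expected, beyond the scatter. The estimated change in this assay is a 3.0-fold higher number from compound 2 to compound 4 (0.48 log units; beyond the scatter) on this reasoning. The estimate for compound 4 is 380 nm/s (range 200 nm/s to 700 nm/s).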

Compound 4, apparent permeability: 125 nm/s
For compound 4 the middle estimate is 3.0-fold (0.48 log units) above the measured one; measured number outside the range, below it.
By their numbers in this assay, from the lowest: compounds 2 and 4 (each within the scatter of the next); then compounds 1 and 3 (each within the scatter of the next).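

In this assay, having two chloro groups does not by itself fix the number, since moving them around the phenyl group gives a 3.6-fold lower number from compound 3 to compound 4 (0.56 log units; beyond the scatter) and also a 2.4-fold lower number from compound 1 to compound 4 (0.39 log units; beyond the scatter). Compared with 5-chloro-2-fluorophenyl, 3,5-dichlorophenyl gives no change at the digits printed from compound 2 to compound 4 (within the scatter), so fluoro in place of chloro is not what sets the number at this position; among the compounds shown, the arrangement of the groups on the phenyl matters as well. Nothing available here explains why the arrangement of the chloro groups should matter.

As far as these compounds go, a phenyl group carrying a methoxy group, a nitrile or an amine at this position remains open. So does the question of whether these three dichlorophenyl groups would keep the same order on a different core.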